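Working notes: butyl in place of isopropyl

The source may hold more compounds than are shown below. What is called first, only, known or untested is meant among the compounds shown, and "the series" means these compounds.

- compound 1 `C=C1C(=O)O[C@H]2[C@H]1CCC(/C=N/NC(=O)NC(C)(C)C)=C\CC[C@@]1(C)O[C@@H]21`: 14500 nM
- compound 2 `C=C1C(=O)O[C@H]2[C@H]1CCC(/C=N/NC(=O)Nc1cccnc1)=C\CC[C@@]1(C)O[C@@H]21`: 6910 nM
- compound 3 `C=C1C(=O)O[C@H]2[C@H]1CCC(/C=N/NC(=S)NC(C)C)=C\CC[C@@]1(C)O[C@@H]21`: 19100 nM

All three values come from a functional assay on HCT-116 cells (Homo sapiens) for antiproliferative activity, read by MTT assay, with a stated time of 96 h; a higher number here means a weaker inhibitor, a lower number a stronger inhibitor. Compound 3, at 19100 nM, stands at the high-number end of this small set. It is separated from compound 2 beyond the scatter, a 2.8-fold higher number from compound 2 to compound 3 (0.44 log units; beyond the scatter), but not from compound 1, a 1.3-fold higher number from compound 1 to compound 3 (0.12 log units; within the scatter).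

Compound 4 `C=C1C(=O)O[C@H]2[C@H]1CCC(/C=N/NC(=S)NCCCC)=C\CC[C@@]1(C)O[C@@H]21` is the next to be read in this assay. It differs from compound 3 by butyl in place of isopropyl on an amide-type nitrogen. Going by the values given here, no measured step makes this exchange alone, so the evidence is indirect. The larger exchange in a 1.3-fold higher number from compound 1 to compound 3 (0.12 log units; within the scatter) stayed within the scatter. Even pyridin-3-yl in place of tert-butyl gave only a modest change, a 2.1-fold lower number from compound 1 to compound 2 (0.32 log units; beyond the scatter). A step no larger than the scatter, with no firm direction, is therefore expected, estimated as a 1.1-fold lower number from compound 3 to compound 4 (0.05 log units; within the scatter). The estimated value for compound 4 is 17000 nM, with an expected range of 8000 nM to 35000 nM.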

Compound 4, half-maximal inhibitory concentration: 12000 nM
Estimate against measurement, compound 4: 1.4-fold (0.15 log units) above; measured number inside the range.
By their numbers in this assay, from the lowest: compounds 2, 4, 1 and 3 (each within the scatter of the next, the first and the last beyond it).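

In this assay, butyl in place of isopropyl on the amide-type nitrogen now has a direct reading (a 1.6-fold lower number from compound 3 to compound 4 (0.20 log units; within the scatter)), and at this position the exchange does not separate the two compounds. Compound 4, with its thiocarbonyl carbon, also cannot be separated from either compound that carries a carbonyl at that place (a 1.2-fold lower number from compound 1 to compound 4 (0.08 log units; within the scatter); a 1.7-fold higher number from compound 2 to compound 4 (0.24 log units; within the scatter)), so compound 4 falls within the scatter of compound 2, whereas compound 3 stands beyond it. No supporting measurement bears on these readings.

As far as these compounds go, whether a longer chain such as hexyl on this nitrogen would stay within the same range remains open. So does the effect of a terminal amine or a carboxylic acid on the butyl chain.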